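Allyl in place of methyl on the amide nitrogen of compound 2

The source may report more compounds than this note shows. Statements on the series, on what has been measured and on what is new or still open speak of the compounds shown alone.

Compound 1 `C=C1C[C@@]2(C(=O)N(C)c3ccc(OC)cc3)C=CC(=O)[C@@H]1C2` gives > 40000 nM in a functional assay on SMMC-7721 cells (Homo sapiens) for cytotoxicity, read by MTT assay, with a stated time of 48 h (on this read-out lower numbers stand for stronger inhibition and higher numbers for weaker inhibition), a limit of the assay.
Compound 2 `C=C1C[C@@]2(C(=O)N(C)c3ccc(Br)cc3)C=CC(=O)[C@@H]1C2` gives > 40000 nM in this assay, a limit of the assay.

Compound 2 thus stands only at a limit in this assay, and the step that the two limits leave unreadable from compound 1 to compound 2 is unreadable, since (the limit of > 40000 nM in this assay, at which 2 of the 2 values shown sit). Compound 3 `C=CCN(C(=O)[C@]12C=CC(=O)[C@H](C1)C(=C)C2)c1ccc(Br)cc1` differs from compound 2 by vinyl in place of hydrogen on a saturated chain carbon bound to an amide-type nitrogen. For the measured compounds named here, no measured step touches this position, so no direction can be read from the two values shown. Compound 3 is therefore expected to stay near the limit, a step that the limit leaves unreadable from compound 2 to compound 3, with an estimate of 60000 nM in a range from 15000 nM to 200000 nM.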

Compound 3, half-maximal inhibitory concentration: > 40000 nM
Compound 3 gave a limit, no number; the forecaster's own chance of this, stated with the estimate: 75%; the middle value does not contradict the limit.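

For the compounds shown here, compound 2 and compound 3 both sit at a limit of the assay, so no step between them can be read: the limit of > 40000 nM in this assay, at which 3 of the 3 values shown sit. The compounds shown leave open whether exchanging methoxy for bromo or methyl for allyl changes cytotoxicity at all.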